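The source may report more compounds than this note shows. Statements on the series, on what has been measured and on what is new or still open speak of the compounds shown alone.

Working notes on the series. Within the data shown here, in a functional assay on the whole organism (strain NMRI BR) with Mus musculus as the target (on this read-out higher numbers stand for an effect only at larger amounts of compound and lower numbers for an effect already at smaller amounts), compound 3 `O=C1C=C(N2CCNCC2)C(=O)N1c1ccc(Cl)cc1` is the only member with a number, giving 360 mg/kg. The two other values are limits. Compound 1 `CN(C)C1=NC(=O)N(c2ccc(Cl)cc2)C1` shows a limit, > 300 mg/kg. Compound 2 `O=C1C=C(c2ccc(Cl)cc2)C(=O)N1c1ccc(Cl)cc1` likewise shows a limit, > 300 mg/kg. Among the measured compounds shown here, the one connecting step, a step that the limit leaves unreadable from compound 2 to compound 3, cannot be sized because of the limit of > 300 mg/kg in this assay, at which 2 of the 3 values shown sit. Compound 4 `O=C1C=C(N2CCCC2)C(=O)N1c1ccc(Cl)cc1` differs from compound 3 by pyrrolidin-1-yl in place of piperazin-1-yl on a double-bonded ring carbon. For the measured compounds named here, no measured step resolves a change at this ring carbon, so no shift beyond the scatter is expected, and the step from compound 3 to compound 4 is estimated at no change at the digits printed from compound 3 to compound 4 (within the scatter). For compound 4 the expected value in this assay is 360 mg/kg, within 150 mg/kg to 900 mg/kg.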

Compound 4, dose for half-maximal effect: > 300 mg/kg
Compound 4: only a limit was reported; the forecaster's own chance of this, stated with the estimate: 35%; the middle value lies beyond the limit too.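

No new step can be read from compound 4 to compound 2 or compound 3, because the result for compound 4 is only a limit: the limit of > 300 mg/kg in this assay, at which 3 of the 4 values shown sit.

As far as these compounds go, whether pyrrolidin-1-yl or piperazin-1-yl at this ring carbon acts at smaller amounts in this assay stays open.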